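Swapping a thienylmethyl arm for a methylphenyl ring

The source may report more compounds than this note shows. Statements on the series, on what has been measured and on what is new or still open speak of the compounds shown alone.

This account concerns a small set of trifluoroacetyl thiophenes tested in an assay on isolated protein for inhibition of protein deacetylase HDAC6 (Homo sapiens); a higher number here means a weaker inhibitor, a lower number a stronger inhibitor. Compound 1 `O=C(c1ccc(-c2nc(Cc3cccs3)no2)s1)C(F)(F)F` gives 170 nM and stands lowest of the three numbers measured. Compound 3 `O=C(c1ccc(-c2nnc(-c3ccccc3)o2)s1)C(F)(F)F` gives 330 nM, a value within the scatter of that of compound 1, so the two cannot be ranked. Compound 2 `O=C(c1ccc(-c2nc(-c3ccc(C(F)(F)F)cc3)no2)s1)C(F)(F)F` gives 11000 nM, far beyond the scatter from compound 1, and carries a 4-trifluoromethylphenyl ring joined directly to its core.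

Compound 4 `Cc1cccc(-c2noc(-c3ccc(C(=O)C(F)(F)F)s3)n2)c1` has not yet been measured. It differs from compound 1 by 3-methylphenyl in place of (thiophen-2-yl)methyl on an aromatic carbon. Among the compounds with values here, no step between measured compounds matches this change. Within the data shown here, the only measured compound with a benzene ring set directly on the same core as compound 1 is compound 2, whose value of 11000 nM is much higher than that of compound 1, whereas compound 3 keeps a low value with a phenyl ring on a differently arranged core. Weighing both, the author expects compound 4 to give a higher number than compound 1, with a step of an 8.8-fold higher number from compound 1 to compound 4 (0.95 log units; beyond the scatter) beyond the scatter but smaller than the gap to compound 2. The estimate for compound 4 is 1500 nM, with a range from 300 nM to 8000 nM.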

Compound 4, half-maximal inhibitory concentration: 680 nM
Beside the measured number, compound 4's estimate is 2.2-fold (0.34 log units) above it, and the stated range covers the measured number.
By their numbers in this assay, from the lowest: compounds 1 and 3 (each within the scatter of the next); then compound 4; then compound 2.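

In this assay, within the data shown here, replacing (thiophen-2-yl)methyl with 3-methylphenyl on an aromatic carbon of the shared core gives the first direct reading of a change at this position: a 4.0-fold higher number from compound 1 to compound 4 (0.60 log units; beyond the scatter), a modest step that lies beyond the scatter. It also shows that a benzene ring set directly on this core need not give a number as high as the one seen earlier, for compound 4 gives 680 nM while compound 2, with 4-trifluoromethylphenyl at the same position, gives 11000 nM. Nothing measured here bears on the reason for the step from the thienylmethyl arm to the methylphenyl ring.

The compounds shown leave open whether the step follows the change of ring or the loss of the carbon link to the core; none carries a benzyl group or a thiophen-2-yl ring set directly on that core. They also leave open what an unsubstituted phenyl ring gives on this core, and how a methoxy group or an amine on the benzene ring would read.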